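The source may report more compounds than this note shows. Statements on the series, on what has been measured and on what is new or still open speak of the compounds shown alone.

Compound 1 `CC1(C#Cc2cncc(-c3ccc4c(c3)[C@@]3(COC(N)=N3)c3cc(C5=CCOCC5)ncc3O4)c2)COC1`: 18 nm/s
Compound 2 `COc1cc2c(cn1)Oc1ccc(NC(=O)c3ccc(Cl)cn3)cc1[C@@]21COC(N)=N1`: 25 nm/s
Compound 3 `Cc1cc2c(cn1)Oc1ccc(NC(=O)c3ccc(Cl)cn3)cc1[C@@]21COC(N)=N1`: 40 nm/s

In an ADME assay on LLC-PK1 cells (Sus scrofa) for permeability, read by LC-MS, with a stated time of 2 h, tested at 5 uM (on this read-out lower numbers stand for lower permeability and higher numbers for higher permeability), compound 1 gives 18 nm/s, the smallest of the three numbers shown, though compound 2 lies within the scatter of it; only compound 3 stands beyond the scatter above it. The one measured step among these compounds is a 1.6-fold higher number from compound 2 to compound 3 (0.20 log units; within the scatter), a change on an aromatic carbon of the shared core that has nothing in common with the change now considered.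

Compound 4 `NC1=N[C@@]2(CO1)c1cc(-c3cncc(C#CC4CC4)c3)ccc1Oc1cnc(C3=CCOCC3)cc12` differs from compound 1 by cyclopropyl in place of 3-methyloxetan-3-yl on a triple-bonded carbon. Within the data shown here, no measured step involves this change, so the expectation rests on nothing firmer than the narrow spread of the three values given, all of which sit within a modest band. The expected step is a 1.7-fold higher number from compound 1 to compound 4 (0.22 log units; within the scatter), a shift that would stay within the scatter of this assay. Compound 4 is therefore estimated to give 30 nm/s, with a likely range from 12 nm/s to 75 nm/s.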

Compound 4, apparent permeability: 13 nm/s
Beside the measured number, compound 4's estimate is 2.3-fold (0.36 log units) above it; low and high end bracket the measured number.
By their numbers in this assay, from the lowest: compounds 4, 1, 2 and 3 (each within the scatter of the next, the first and the last beyond it).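

This is the first step shown at this place on the shared core: in this assay, cyclopropyl in place of 3-methyloxetan-3-yl on a triple-bonded carbon gives a 1.4-fold lower number from compound 1 to compound 4 (0.14 log units; within the scatter) and stays within the scatter. The group can therefore go from 5 heavy atoms with 1 hydrogen-bond acceptor to 3 heavy atoms with 0 hydrogen-bond acceptors without the read-out separating the two compounds. Nothing shown accounts for this result.

The compounds shown leave open whether a group of another kind on the same triple-bonded carbon, such as an amine, a carboxylic acid or a longer carbon chain, would also stay within the scatter of compound 1. They also leave open whether this single pair would read the same way on a different core.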